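From Methyl to Nitro: Expecting Compound 3's Inhibition

The source may report more compounds than this note shows. Statements on the series, on what has been measured and on what is new or still open speak of the compounds shown alone.

Going by the values given here, compound 2 `CC(=O)c1cccc(OCc2cccc(C)c2)c1` gives 893 nM in an assay on isolated protein for inhibition of Amine oxidase [flavin-containing] B (Homo sapiens), read by Amplex Red, with a stated time of 15 min (on this read-out higher numbers stand for weaker inhibition and lower numbers for stronger inhibition), the highest of the two numbers measured so far. Its nearest neighbour, compound 1 `CC(=O)c1cccc(OCc2cccc(Br)c2)c1`, gives 96.3 nM in this assay. Compound 3 `CC(=O)c1cccc(OCc2cccc([N+](=O)[O-])c2)c1` differs from compound 2 by nitro in place of methyl on an aromatic carbon. Among the compounds with values here, the only measured step, a 9.3-fold higher number from compound 1 to compound 2 (0.97 log units; beyond the scatter), shows that the group at this position matters clearly, but no measured step swaps methyl for nitro, so nitro has no direct precedent. A step of moderate size toward a lower number is therefore expected. Compound 3 is estimated at 300 nM (range 60 nM to 1500 nM), meaning a 3.0-fold lower number from compound 2 to compound 3 (0.47 log units; beyond the scatter).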

Compound 3, half-maximal inhibitory concentration: 114 nM
Estimate against measurement, compound 3: 2.6-fold (0.42 log units) above; low and high end bracket the measured number.
By their numbers in this assay, from the lowest: compounds 1 and 3 (each within the scatter of the next); then compound 2.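

Nitro in place of methyl brings a 7.8-fold lower number from compound 2 to compound 3 (0.89 log units; beyond the scatter) in this assay and shows that bromo is not the only group at this position that gives a clearly lower number than methyl. Nitro in place of bromo brings a 1.2-fold higher number from compound 1 to compound 3 (0.07 log units; within the scatter) and so these two groups cannot be told apart in this assay at this position, while methyl stands apart from both. Going by these compounds, whether an amine, a carboxylic acid or a longer chain here would keep the lower number remains open. Nothing given here accounts for the difference between methyl and the other two groups.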